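Methoxy for fluoro on the pyrazole aryl of compound 2

This account rests on a few compounds, and the source may have more. Where it says the series, first, only, none or still open, it means among the compounds named here.

Three enaminones sharing one core have been tested in a functional assay on A549 cells (Homo sapiens) for antiproliferative activity, read by MTT assay, with a stated time of 48 h; a lower number here means a stronger inhibitor, a higher number a weaker inhibitor. Compound 1 `COc1ccc(N/C=C\C(=O)c2cn(-c3ccccc3)nc2-c2ccc(F)cc2)cc1` gives 8900 nM, and compound 2 `COc1cc(N/C=C\C(=O)c2cn(-c3ccccc3)nc2-c2ccc(F)cc2)cc(OC)c1OC` gives 9350 nM. Compound 3 `O=C(/C=C\Nc1ccc(C(F)(F)F)cc1)c1cn(-c2ccccc2)nc1-c1ccc(Cl)cc1` reaches only the limit of the assay, > 50000 nM, so for it no number is known; that limit is the point noted in the limit of > 50000 nM in this assay, at which 1 of the 3 values shown sits. Among the two numbers available, compound 2 has the higher one, yet it sits so close to compound 1 that the two cannot be told apart within the scatter of this assay, and neither can be called the stronger.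

Compound 4 `COc1ccc(-c2nn(-c3ccccc3)cc2C(=O)/C=C\Nc2cc(OC)c(OC)c(OC)c2)cc1` differs from compound 2 in one place: methoxy in place of fluoro on an aromatic carbon, the trimethoxyanilino part being kept. Among the measured compounds shown here, no pair measured here isolates this change, so its effect is not known from the data at hand. The step from compound 2 to compound 4 is therefore expected to be small, close to none beyond the scatter, a 1.0-fold lower number from compound 2 to compound 4 (0.02 log units; within the scatter). Compound 4 is accordingly estimated at 9000 nM in this assay, with a plausible range from 3000 nM to 30000 nM.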

Compound 4, half-maximal inhibitory concentration: 11200 nM
Beside the measured number, compound 4's estimate is 1.2-fold (0.09 log units) below it; measured number inside the range.
By their numbers in this assay, from the lowest: compounds 1, 2 and 4 (each within the scatter of the next). At a limit, above all of these: compound 3.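

In this assay, the exchange of 4-fluorophenyl for 4-methoxyphenyl, with the trimethoxyanilino part kept, gives a 1.2-fold higher number from compound 2 to compound 4 (0.08 log units; within the scatter). Among the compounds shown here, this is the first pair that isolates a change at this position, on the aromatic carbon para to a large group, and it shows that a single fluorine can give way to methoxy, with its 2 heavy atoms and 1 hydrogen-bond acceptor, without a difference that can be told from the scatter; the result rests on this one pair and on this one anilino part. Nothing measured here gives a cause for this result, and the data cannot say whether the two groups act alike at this position or whether the assay simply does not respond to them.

On these data alone, whether the same exchange holds with the anilino part of compound 1 stays open, as does what an amine, a carboxylic acid or a longer alkoxy chain would do at this position. For the compounds shown here, compound 3, at > 50000 nM, stands at a limit of the assay and not at a number, and it differs from the other compounds in more than one place, so it gives no step that can be read here.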